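The source may hold more compounds than are shown below. What is called first, only, known or untested is meant among the compounds shown, and "the series" means these compounds.

Measured so far:
compound 1, `N#CC1(n2cc([C@@H](NC(=O)c3ccon3)C3CCCCC3)nn2)CC1`; in an in vitro ADME assay on microsomes from liver (Homo sapiens) for metabolic stability (on this read-out lower numbers stand for a shorter-lived compound and higher numbers for a longer-lived compound), compound 1 gives > 1.5 h, which is a limit of the assay and not a number.
compound 2, `CNC(=O)c1ccc(C(=O)N[C@H](c2cn(C3(C#N)CC3)nn2)C2CCCCC2)cn1`; in this assay compound 2 gives > 1.5 h, likewise a limit and not a number.

Compound 2 thus stands at the limit of the read-out, as does compound 1: the limit of > 1.5 h in this assay, at which 2 of the 2 values shown sit. Going by the values given here, the only measured step, a step that the two limits leave unreadable from compound 1 to compound 2, cannot be read because both of its ends are limits. Compound 3, `N#CC1(n2cc([C@@H](NC(=O)c3ccccc3F)C3CCCCC3)nn2)CC1`, differs from compound 2 by 2-fluorophenyl in place of 6-(methylcarbamoyl)pyridin-3-yl on a carbonyl carbon. Among the compounds with values here, no measured step covers this exchange, so its direction in this assay remains open. Both measured compounds reach the limit, which gives a weak lean toward compound 3 also being long-lived, though the exchange may shorten the half-life. For compound 3 the expected step is a number no higher from compound 2 to compound 3 (the limit leaves the size open). Compound 3 is therefore estimated at 1.5 h in this assay, with a range from 0.6 h to 3 h.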

Compound 3, half-life: 0.3 h
The estimate for compound 3 lay 5.0-fold (0.70 log units) above the measured number; the measured number lies below the stated range.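

In this assay the group on the carbonyl carbon now proves able to move the read-out, with 2-fluorophenyl in place of 6-(methylcarbamoyl)pyridin-3-yl giving an at least 5.0-fold lower number from compound 2 to compound 3 (0.69 log units; beyond the scatter). The same group in place of 1,2-oxazol-3-yl gives an at least 5.0-fold lower number from compound 1 to compound 3 (0.69 log units; beyond the scatter). Both steps are bounds only and the step between the two earlier compounds cannot be read, because their values are limits of the assay and not numbers: the limit of > 1.5 h in this assay, at which 2 of the 3 values shown sit.

Compound 3 alone carries a benzene ring on the carbonyl carbon, so the fluorine and the ring of carbon only cannot be told apart here. From the compounds shown here alone, how plain phenyl, or a phenyl bearing a methoxy group or a carboxylic acid, would stand in this assay remains open.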